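The compounds below may be only part of what the source reports. "The series", "measured", "known", "first", "only" and "open" are said of these compounds alone.

In an assay on CHO cells for displacement of a labelled ligand from Alpha-2B adrenergic receptor (Homo sapiens) (on this read-out higher numbers stand for weaker inhibition and lower numbers for stronger inhibition), compound 1 `CC(Oc1ccccc1Br)C1=NCCN1` gives 355 nM, compound 2 `CCc1ccccc1OC(C)C1=NCCN1` gives 282 nM, and compound 3 `CCOc1ccccc1OC(C)C1=NCCN1` gives 1320 nM, the highest of the three numbers; the nearest is a 3.7-fold higher number from compound 1 to compound 3 (0.57 log units; beyond the scatter), the furthest is a 4.7-fold higher number from compound 2 to compound 3 (0.67 log units; beyond the scatter). Compound 4 `CC(Oc1ccccc1OC1CC1)C1=NCCN1` differs from compound 3 by cyclopropyl in place of ethyl on an oxygen on an aromatic ring. Among the compounds with values here, no measured step changes the group on that oxygen; the two steps that touch this part of the core, a 3.7-fold higher number from compound 1 to compound 3 (0.57 log units; beyond the scatter) and a 4.7-fold higher number from compound 2 to compound 3 (0.67 log units; beyond the scatter), replace the whole substituent on the aromatic carbon and therefore bear on it only loosely. With no closer guide, compound 4 is expected to stay near compound 3, with a 1.1-fold lower number from compound 3 to compound 4 (0.04 log units; within the scatter) lying within the scatter, so compound 4 is estimated at 1200 nM in this assay, with a range of 450 nM to 3500 nM.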

Compound 4, inhibition constant: 1050 nM
Estimate against measurement, compound 4: 1.1-fold (0.06 log units) above; low and high end bracket the measured number.
By their numbers in this assay, from the lowest: compounds 2 and 1 (each within the scatter of the next); then compounds 4 and 3 (each within the scatter of the next).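

In this assay, changing the group on the oxygen on an aromatic ring from ethyl to cyclopropyl, and so adding a three-membered ring, leaves the number within the scatter (a 1.3-fold lower number from compound 3 to compound 4 (0.10 log units; within the scatter)). The higher number seen with ethoxy therefore also holds for cyclopropyloxy, both against ethyl (a 3.7-fold higher number from compound 2 to compound 4 (0.57 log units; beyond the scatter)) and against bromo (a 3.0-fold higher number from compound 1 to compound 4 (0.47 log units; beyond the scatter)). Nothing measured here accounts for these differences. On these data alone, whether a longer chain such as butyl, or an amine, on that oxygen would keep the number at this level remains open.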